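The compounds below may be only part of what the source reports. "The series", "measured", "known", "first", "only" and "open" are said of these compounds alone.

Compound 1 `O=C1C=C(N2CCN(c3ccccc3)CC2)C(=O)c2ccccc21` gives 9900 nM
Compound 2 `O=C1C=C(N2CCC(c3ccc(Cl)cc3)CC2)C(=O)c2c(O)cccc21` gives 2600 nM

Among the measured compounds shown here, both values come from a functional assay on DU-145 cells (Homo sapiens) for inhibition, read by MTT assay, with a stated time of 72 h (a lower number here means a stronger inhibitor, a higher number a weaker inhibitor), and are the only measurements so far. Compound 2 holds the lower of the two numbers, and compound 1 stands above it by a gap beyond the usual scatter. For the measured compounds named here, no two measured compounds differ in one place only, so no measured step bears directly on what comes next.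

Compound 3 `Cc1ccccc1C1CCN(C2=CC(=O)c3cccc(O)c3C2=O)CC1` has yet to be measured in this assay and departs from compound 2 in a single place: 2-methylphenyl in place of 4-chlorophenyl on a saturated ring carbon, with 2-methylphenyl in place of 4-chlorophenyl on a saturated ring carbon. Going by the values given here, nothing measured so far shows what this exchange does, so the expectation starts from compound 2 at 2600 nM and allows for a modest drift toward a weaker number. The expected change is a 1.3-fold higher number from compound 2 to compound 3 (0.13 log units; within the scatter), a small step toward a higher number that may well stay within the scatter. For compound 3 the estimated value is 3500 nM, with an expected range from 1400 nM to 9000 nM.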

Compound 3, half-maximal inhibitory concentration: 2500 nM
The estimate for compound 3 lay 1.4-fold (0.15 log units) above the measured number, and the stated range covers the measured number.
By their numbers in this assay, from the lowest: compounds 3 and 2 (each within the scatter of the next); then compound 1.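

In this assay, among the compounds shown here, placing 2-methylphenyl instead of 4-chlorophenyl on the saturated ring carbon, three ring bonds from the ring nitrogen, gives a 1.0-fold lower number from compound 2 to compound 3 (0.02 log units; within the scatter) and so provides the first direct reading at this position. Both groups have one six-membered aromatic ring of carbon only, no hydrogen-bond donors or acceptors and no net charge, and this single exchange of the chlorine-bearing ring for the methyl-bearing ring separates the two compounds by no more than the usual scatter. Nothing available explains why the two groups read alike.

The compounds shown leave open whether this equivalence extends beyond these two substituted phenyl groups, for instance to unsubstituted phenyl, to 4-methylphenyl and 2-chlorophenyl, which would separate the identity of the substituent from its place on the ring, or to a group of another kind, such as a pyridine ring, an amine or a carboxylic acid. Compound 1 differs from compound 2 and from compound 3 in more than one place, so its number cannot be tied to any single change, and the part played by the rest of the molecule remains unresolved.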